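This account rests on a few compounds, and the source may have more. Where it says the series, first, only, none or still open, it means among the compounds named here.

Compound 1 `COc1cncc(N2CCCNCC2)c1` gives 1410 nM in a functional assay on HEK293 cells for agonist activity at Neuronal acetylcholine receptor; alpha4/beta2 (Homo sapiens), read by FLIPR and calcium flux (on this read-out lower numbers stand for an effect already at smaller amounts and higher numbers for an effect only at larger amounts of compound), compound 2 `C/C=C\Oc1cncc(N2CCCNCC2)c1` gives 2090 nM, and compound 3 `NC(=O)c1cncc(N2CCCNCC2)c1` gives 12900 nM, the highest of the three numbers, with both other compounds beyond the scatter below it. Compound 4 `C=COc1cncc(N2CCCNCC2)c1` has not yet been tested. The change from compound 3 to compound 4 is vinyloxy in place of carbamoyl on an aromatic carbon. Within the data shown here, two measured steps bear on it, run in the opposite direction: a 9.1-fold higher number from compound 1 to compound 3 (0.96 log units; beyond the scatter) and a 6.2-fold higher number from compound 2 to compound 3 (0.79 log units; beyond the scatter), both beyond the scatter, while a 1.5-fold higher number from compound 1 to compound 2 (0.17 log units; within the scatter) shows that methyl and prop-1-en-1-yl on the oxygen hardly differ. Because compound 3 stands at 12900 nM and the alkoxy compounds sit lower, compound 4 is expected to show a step of a 7.6-fold lower number from compound 3 to compound 4 (0.88 log units; beyond the scatter) and a value near 1700 nM, with a range from 800 nM to 3600 nM.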

Compound 4, half-maximal effective concentration: 1100 nM
Compound 4: the middle estimate sits 1.5-fold (0.19 log units) above what was measured; low and high end bracket the measured number.
By their numbers in this assay, from the lowest: compounds 4, 1 and 2 (each within the scatter of the next); then compound 3.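

In this assay, the swap of carbamoyl for vinyloxy on this aromatic carbon leaves the heavy-atom count and the double bond outside aromatic rings unchanged, yet gives a 12-fold lower number from compound 3 to compound 4 (1.07 log units; beyond the scatter) as hydrogen-bond donors go from 1 to 0. On the oxygen, vinyl adds a third small group with no change beyond the scatter, with a 1.3-fold lower number from compound 1 to compound 4 (0.11 log units; within the scatter) and a 1.9-fold lower number from compound 2 to compound 4 (0.28 log units; within the scatter) on the same footing. No measurement here explains the large step. Still open, going by these compounds, is how an amine or a carboxylic acid would behave at this carbon, and whether a longer chain on the oxygen would also leave the number in place.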